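The source may report more compounds than this note shows. Statements on the series, on what has been measured and on what is new or still open speak of the compounds shown alone.

Compound 1 `CC(C)(C)OC(=O)N1CCC(Oc2cccc3c2CCN3c2ccc(S(C)(=O)=O)cc2)CC1`, compound 2 `CC(C)OC(=O)N1CCC(Oc2ncnc3c2CCN3c2ccc(C#N)cc2F)CC1` and compound 3 `CCCCOC(=O)N1CCC(Oc2ncnc3c2CCN3c2ccc(S(C)(=O)=O)cc2F)CC1` share the same general arrangement and differ in the group on the ring nitrogen and in the aryl substituents. In a functional assay on CHO-K1 cells for agonist activity at Glucose-dependent insulinotropic receptor (Homo sapiens), read by a luciferase reporter, with a stated time of 5 h (a lower number here means that less compound is needed, a higher number that more compound is needed for the effect), compound 1 gives 158 nM, compound 2 gives 63.1 nM, and compound 3 gives 50.1 nM. Compound 3 has the lowest number of the three; its gap to compound 2 lies within the scatter, its gap to compound 1 beyond it. Compound 4 `CS(=O)(=O)c1ccc(N2CCc3c(OC4CCN(C(=S)Sc5ccccc5)CC4)ncnc32)c(F)c1` is not yet measured and differs from compound 3 in one place: a group of 9 heavy atoms (7 carbon, 2 sulfur; one six-membered aromatic ring of carbon only) in place of a group of 7 heavy atoms (5 carbon, 2 oxygen; no ring), on an amine nitrogen in a ring. Among the measured compounds shown here, no measured pair isolates this change, and the entering group has no counterpart among the measured compounds. The expectation for compound 4 is a moderate step toward a higher number, a 2.4-fold higher number from compound 3 to compound 4 (0.38 log units; beyond the scatter), with wide uncertainty. Compound 4 is estimated at 120 nM, with a range from 30 nM to 500 nM.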

Compound 4, half-maximal effective concentration: 12.6 nM
For compound 4 the middle estimate is 9.5-fold (0.98 log units) above the measured one; the whole stated range lies above it.
By their numbers in this assay, from the lowest: compound 4; then compounds 3 and 2 (each within the scatter of the next); then compound 1.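

On the amine nitrogen in the ring, butoxycarbonyl is not required for activity in this assay: replacing it with the sulfur-containing group bearing a six-membered aromatic ring gives a 4.0-fold lower number from compound 3 to compound 4 (0.60 log units; beyond the scatter) and a result beyond the scatter. This position therefore accepts a group with more heavy atoms and an aromatic ring without loss of agonist potency. Nothing measured here explains the step.

A phenoxycarbonyl group would test the aromatic ring without the sulfur atoms, and a butyl chain on the same sulfur-containing linkage would test the sulfur atoms without that ring. Going by these compounds, whether the step carries over to the nitrile-bearing aryl group of compound 2 remains open.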